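A few compounds are considered here, and "the series" means these few. Any claim that something is new, unique, unknown or untested is made for them only; others in the source may bear on it.

Three compounds were tested in an ADME assay on Vero cells (Chlorocebus sabaeus) for cytotoxicity, read by resazurin assay, with a stated time of 72 h (a higher number here means that more compound is tolerated, a lower number that less compound is tolerated), and a fourth awaits measurement. Compound 1, `CC(C)=CCOc1ccc(C(=O)/C=C/c2cccnc2)c(O)c1`, gave 210000 nM in this assay. Compound 3, `C#CCOc1ccc(C(=O)/C=C/c2cccnc2)c(O)c1`, differs from compound 1 only by ethynyl in place of 2-methylprop-1-en-1-yl on a saturated chain carbon bound to an oxygen on an aromatic ring, and compound 3 gave 40000 nM; this single change made a 5.3-fold lower number from compound 1 to compound 3 (0.72 log units; beyond the scatter), so less of compound 3 was tolerated by the cells.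

Compound 2, `COc1cc(OCC=C(C)C)ccc1C(=O)/C=C/c1ccncc1`, gave 16000 nM in this assay, the lowest of the three numbers; the difference between its core and the core of compound 1 is not broken down here.

Going by the values given here, compound 4, `C#CCOc1ccc(C(=O)/C=C/c2ccncc2)c(OC)c1`, carries the same change as the one seen between compound 1 and compound 3, namely (ethynyl in place of 2-methylprop-1-en-1-yl on a saturated chain carbon bound to an oxygen on an aromatic ring), and the surroundings of the change are the same in both pairs. Applied to compound 2, this change is expected to make a 4.0-fold lower number from compound 2 to compound 4 (0.60 log units; beyond the scatter) in this assay, because the same change earlier produced a 5.3-fold lower number from compound 1 to compound 3 (0.72 log units; beyond the scatter). Compound 4 is therefore estimated to give about 4000 nM in this assay, with a likely range from 1500 nM to 12000 nM.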

Compound 4, half-maximal cytotoxic concentration: 20000 nM
Beside the measured number, compound 4's estimate is 5.0-fold (0.70 log units) below it; measured number outside the range, above it.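

Putting ethynyl in place of 2-methylprop-1-en-1-yl does not carry a fixed effect from one core to another in this series: in this assay the change gave a 1.3-fold higher number from compound 2 to compound 4 (0.10 log units; within the scatter) and so left compound 2 and compound 4 indistinguishable, unlike the clear step seen on the core of compound 1. The two steps themselves differ by more than ordinary repeat variation, so the effect of this change depends on the core it sits on: the same change on two cores in this assay, a 5.3-fold lower number (0.72 log units; beyond the scatter) from compound 1 to compound 3 and a 1.3-fold higher number (0.10 log units; within the scatter) from compound 2 to compound 4, 6.6-fold (0.82 log units) apart, beyond the scatter of two such steps.

Going by these compounds alone, this comparison rests on only two pairs, so it does not show which part of the core sets the size of the step, nor how the change would behave on a third core.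

The compounds shown leave open which of the differences between the two cores matters. Also open, going by these compounds, is how a longer chain, an amine or a carboxylic acid at this place, on a saturated chain carbon bound to an oxygen on an aromatic ring, would fare in this assay on either core.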